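A few compounds are considered here, and "the series" means these few. Any claim that something is new, unique, unknown or untested is made for them only; others in the source may bear on it.

Measured so far:
- compound 1 (`O=C(Nc1ccc(C(=O)N2CCCCc3sccc32)cc1OCCCC(=O)N1CCC(N2CCCCC2)CC1)c1ccccc1-c1ccccc1`): 0.03 mg/kg
- compound 2 (`COc1cc(C(=O)N2CCCC(N(C)C)c3sccc32)ccc1NC(=O)c1ccccc1-c1ccccc1`): > 0.3 mg/kg
- compound 3 (`O=C(Nc1ccc(C(=O)N2CCCN(CCN3CCCC3)c3sccc32)cc1)c1ccccc1-c1ccccc1`): > 0.3 mg/kg

For the measured compounds named here, in a functional assay on the whole organism for antagonist activity, with Rattus norvegicus as the target (a lower number here means that less compound is needed, a higher number that more compound is needed for the effect), compound 1 gives 0.03 mg/kg, the only true number among the three. For compound 2 the result is a limit, > 0.3 mg/kg, not a number. For compound 3 the result is likewise a limit, > 0.3 mg/kg. So two of the three entries sit at the limit of > 0.3 mg/kg in this assay, at which 2 of the 3 values shown sit, and compound 1 alone stands as a measured dose.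

Compound 4 (`CN1CCCN(C(=O)CCCOc2cc(C(=O)N3CCCCc4sccc43)ccc2NC(=O)c2ccccc2-c2ccccc2)CC1`) differs from compound 1 in one place: 4-methyl-1,4-diazepan-1-yl in place of 4-(piperidin-1-yl)piperidin-1-yl on a carbonyl carbon. Going by the values given here, no measured pair in this set shows such a swap, so the size of the step can only be guessed; a change staying within the scatter, or a small loss, is expected. Compound 4 is estimated at 0.05 mg/kg, between 0.02 mg/kg and 0.15 mg/kg, meaning an expected step of a 1.7-fold higher number from compound 1 to compound 4 (0.22 log units; within the scatter).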

Compound 4, dose for 50% inhibition: 0.008 mg/kg
The estimate for compound 4 lay 6.3-fold (0.80 log units) above the measured number; measured number outside the range, below it.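

In this assay, putting 4-methyl-1,4-diazepan-1-yl in place of 4-(piperidin-1-yl)piperidin-1-yl on the carbonyl carbon gives a 3.8-fold lower number from compound 1 to compound 4 (0.57 log units; beyond the scatter), a modest step beyond the scatter. This first one-place comparison shows that the position tolerates a single seven-membered ring with fewer heavy atoms in place of the two six-membered rings, and that less compound is then needed. Nothing shown explains why the number moves.

Still open, on these data alone, is how a morpholin-4-yl group or a simple dimethylamino-free primary amine on the same carbonyl carbon would compare.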